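The compounds below may be only part of what the source reports. "The series", "measured", "known", "first", "only" and "open" are said of these compounds alone.

Of the compounds shown here, two with a shared core have been measured. Compound 1 `Clc1ccc(/C=C2\CCCN=C2c2cccnc2)cc1` carries a chloro group on its outer aromatic ring and gives 970 nM in an assay on membranes from brain for displacement of a labelled ligand from Neuronal acetylcholine receptor; alpha4/beta2 (Rattus norvegicus), with a stated time of 3 h; on this read-out higher numbers stand for weaker inhibition and lower numbers for stronger inhibition. Compound 2 `CSc1ccc(/C=C2\CCCN=C2c2cccnc2)cc1` carries a methylsulfanyl group in the same place and gives 900 nM in this assay. The step between them, a 1.1-fold lower number from compound 1 to compound 2 (0.03 log units; within the scatter), is too small to mean anything, so compound 2 stands at the bottom of the two numbers only nominally, with compound 1 beside it inside the scatter.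

Compound 3 `N#Cc1ccc(/C=C2\CCCN=C2c2cccnc2)cc1` is the next variation: cyano in place of methylsulfanyl on an aromatic carbon. Within the data shown here, the only measured step that bears on this change is the exchange of one such group for another at this position, from compound 1 to compound 2, and that exchange barely moved the number. With just one such comparison, and with both groups so far giving nearly the same result, the expectation for compound 3 is a step of a 1.2-fold higher number from compound 2 to compound 3 (0.09 log units; within the scatter) in this assay, that is, nothing beyond the scatter. Compound 3 is therefore estimated at 1100 nM, with a range from 400 nM to 3000 nM.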

Compound 3, inhibition constant: 1230 nM
Beside the measured number, compound 3's estimate is 1.1-fold (0.05 log units) below it, and the stated range covers the measured number.
By their numbers in this assay, from the lowest: compounds 2, 1 and 3 (each within the scatter of the next).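

Cyano is a third group on this aromatic carbon, para to a large group, and the comparisons give a 1.4-fold higher number from compound 2 to compound 3 (0.14 log units; within the scatter) and a 1.3-fold higher number from compound 1 to compound 3 (0.10 log units; within the scatter) in this assay for this exchange. Where the earlier compounds offered a single pair, there are now three groups, chloro, methylsulfanyl and cyano, whose numbers all lie within the scatter of one another, so this read-out has not yet separated any of the groups tried at this position, even though the nitrile brings a triple bond that neither of the other two has. No measurement is available that could explain why the three numbers lie so close together.

Among these compounds, because every step so far stays within the scatter, it remains open whether this position can influence the number at all, or whether these three groups simply happen to give similar results. An amine, a carboxylic acid or a longer chain such as butyl on the same carbon would test this, and the shared core would stay the same, so that any larger step could be traced to that one place.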